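The source may report more compounds than this note shows. Statements on the series, on what has been measured and on what is new or still open speak of the compounds shown alone.

Compound 1 `CN1CCN(c2cc(C(F)(F)F)ccc2[C@H]2CCOc3cc(S(=O)(=O)Nc4nccs4)ccc32)CC1` gives 2.1 in a physicochemical assay for lipophilicity (on this read-out lower numbers stand for lower lipophilicity and higher numbers for higher lipophilicity), compound 2 `O=C1OCCN1c1cc(C(F)(F)F)ccc1[C@H]1CCOc2cc(S(=O)(=O)Nc3nccs3)ccc21` gives 2.1, and compound 3 `Cn1nccc1-c1cc(C(F)(F)F)ccc1[C@H]1CCOc2cc(S(=O)(=O)Nc3nccs3)ccc21` gives 2.2. Compound 3 thus stands level with the other two within the scatter, as a number 0.10 log units higher from compound 1 to compound 3 (within the scatter) and a number 0.10 log units higher from compound 2 to compound 3 (within the scatter) show. Compound 4 `O=S(=O)(Nc1nccs1)c1ccc2c(c1)OCC[C@@H]2c1ccc(C(F)(F)F)cc1-c1ccc(F)cc1` differs from compound 3 in one place: 4-fluorophenyl in place of 1-methyl-1H-pyrazol-5-yl on an aromatic carbon. Only those two steps bear on this change, and only loosely, for each exchanges groups containing hetero atoms, whereas here a ring of carbon only enters. Going by the values given here, with no measured step of this kind, the expectation rests on the structural change itself and is correspondingly uncertain. A rise beyond the scatter is expected in this assay, an estimated a number 0.80 log units higher from compound 3 to compound 4 (beyond the scatter). Compound 4 is estimated at 3, with an expected range from 2.5 to 3.6.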

Compound 4, distribution coefficient: 4.5
Beside the measured number, compound 4's estimate is 1.50 log units below it; the measured number lies above the stated range.
By their numbers in this assay, from the lowest: compounds 1, 2 and 3 (each within the scatter of the next); then compound 4.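

In this assay this position had seemed indifferent to which of the three nitrogen-containing groups it carried, but 4-fluorophenyl, with its six-membered aromatic ring of carbon only, gives a number 2.30 log units higher from compound 3 to compound 4 (beyond the scatter), a number 2.40 log units higher from compound 2 to compound 4 (beyond the scatter) and a number 2.40 log units higher from compound 1 to compound 4 (beyond the scatter). The position is therefore not insensitive to its substituent, and the three earlier exchanges did not reveal how far the read-out could move. No available evidence explains the size of these steps. Going by these compounds, whether the step belongs to the fluorine or to the ring of carbon only remains open; a plain phenyl or a pyridine ring at this position would separate the two.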